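A Small Ring Swap on an Amide Nitrogen

The source may report more compounds than this note shows. Statements on the series, on what has been measured and on what is new or still open speak of the compounds shown alone.

A half-life tells how quickly a compound disappears from the body, and small changes to a structure can shift it. In an in vivo ADME assay on the whole organism (strain Sprague-Dawley) for metabolic stability, with Rattus norvegicus as the target (on this read-out lower numbers stand for a shorter-lived compound and higher numbers for a longer-lived compound), compound 1 (`CC(C)(CC(=O)O)c1ccc(-c2cccc(-n3cc(C(=O)NC4CC4)c(=O)c4cccnc43)c2)cc1`) gives 5.1 h. Compound 2 (`CC1(NC(=O)c2cn(-c3cccc(-c4ccc(C5CC5C(=O)O)cc4)c3)c3ncccc3c2=O)CC1`) gives 4.1 h, which places it within the usual scatter of compound 1, so these two numbers cannot be told apart.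

Compound 3 (`O=C(NC1CCC1)c1cn(-c2cccc(-c3ccc(C4CC4C(=O)O)cc3)c2)c2ncccc2c1=O`) has not yet been measured. It differs from compound 2 in one group, with cyclobutyl in place of 1-methylcyclopropyl on an amide-type nitrogen. The two structures have the same atoms, joined differently. Among the measured compounds shown here, no measured pair here shows what this exchange does, so the only guides are the two close values already in hand, with compound 2 at 4.1 h as the nearest relative. No change beyond the scatter is expected in this assay, and any direction would be tentative. The expected move is a 1.2-fold lower number from compound 2 to compound 3 (0.07 log units; within the scatter), which would stay within the scatter. The estimate for compound 3 is 3.5 h, with an expected range of 1.8 h to 6.5 h.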

Compound 3, half-life: 2.4 h
Estimate against measurement, compound 3: 1.5-fold (0.16 log units) above, and the stated range covers the measured number.
By their numbers in this assay, from the lowest: compounds 3, 2 and 1 (each within the scatter of the next, the first and the last beyond it).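

In this assay, among the compounds shown here, putting cyclobutyl in place of 1-methylcyclopropyl on an amide-type nitrogen gives a 1.7-fold lower number from compound 2 to compound 3 (0.23 log units; within the scatter) as the first direct reading of this exchange. Both groups hold 4 heavy atoms, all carbon, and each is a single non-aromatic ring, one four-membered and the other three-membered, so this pair shows that the same carbon atoms can be joined differently at this position without a change in half-life that can be told from the scatter of repeated measurements. Nothing measured on these compounds speaks to why the two groups compare this way.

On these data alone, both groups are small all-carbon rings, so it remains open how the half-life would respond to a different kind of group on this nitrogen, such as an oxetane ring, which brings in oxygen, or a longer chain such as n-butyl. For the compounds shown here, it is also open whether the exchange would read the same way on a compound carrying the carboxylic acid side chain of compound 1 instead of the one shared by compound 2 and compound 3.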